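This account rests on a few compounds, and the source may have more. Where it says the series, first, only, none or still open, it means among the compounds named here.

Measured compounds:
- compound 1, `Cc1ccc2occ(C3N=C(c4ccccc4)SS3)c(=O)c2c1`: 70700 nM
- compound 2, `O=c1c(C2N=C(c3ccccc3)SS2)coc2ccc(Cl)cc12`: 10000 nM
- compound 3, `O=c1c(C2N=C(c3ccccc3)SS2)coc2cc(Cl)c(Cl)cc12`: 58000 nM

All three were tested in a functional assay on IMR-32 cells (Homo sapiens) for inhibition, read by sulforhodamine B assay, with a stated time of 48 h; on this read-out lower numbers stand for stronger inhibition and higher numbers for weaker inhibition. Compound 3 has the second highest number of the three: compound 1 sits within the scatter of it, while compound 2 gives a clearly lower number, since a 5.8-fold higher number from compound 2 to compound 3 (0.76 log units; beyond the scatter).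

Compound 4, `O=c1c(C2N=C(c3ccccc3)SS2)coc2cc(Cl)ccc12`, has not been measured. It differs from compound 3 by hydrogen in place of chloro on an aromatic carbon. Among the compounds with values here, one measured step bears directly on this change, in the reverse direction: a 5.8-fold higher number from compound 2 to compound 3 (0.76 log units; beyond the scatter), where a chloro was added to an aromatic carbon. Taking a chloro away again, though from the other carbon that carries one, is therefore expected to lower the number. A second step, a 7.1-fold lower number from compound 1 to compound 2 (0.85 log units; beyond the scatter), shows that exchanges on this ring move the number by modest amounts. Compound 4 is an isomer of compound 2, not the same compound, so the full reversal is uncertain, and a somewhat smaller step is expected: a 2.3-fold lower number from compound 3 to compound 4 (0.37 log units; beyond the scatter). The estimate for compound 4 is 25000 nM, within a range of 8000 nM to 70000 nM.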

Compound 4, half-maximal inhibitory concentration: 95100 nM
For compound 4 the middle estimate is 3.8-fold (0.58 log units) below the measured one; the measured number lies above the stated range.
By their numbers in this assay, from the lowest: compound 2; then compounds 3, 1 and 4 (each within the scatter of the next).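

In this assay, taking the chloro away from this aromatic carbon of compound 3 gives a 1.6-fold higher number from compound 3 to compound 4 (0.21 log units; within the scatter) and so leaves the read-out unchanged, as far as repeated measurements can tell. The other chloro of compound 3 behaves differently: the step that adds it, a 5.8-fold higher number from compound 2 to compound 3 (0.76 log units; beyond the scatter), lies beyond the scatter, so the two chloro groups do not count equally in this series. Nothing available explains this difference.

As far as these compounds go, whether the read-out would also stay put with a different group on this carbon remains open, for instance a methoxy group or an amine. With only chloro and hydrogen seen here, the lack of change at this carbon holds for that one exchange and cannot yet be extended to other groups.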